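A few compounds are considered here, and "the series" means these few. Any claim that something is new, unique, unknown or untested is made for them only; others in the source may bear on it.

Measured compounds:
- Compound 1, `C[C@@H](C(=O)N[C@H](C#N)CC(N)=O)N(Cc1ccc(-c2cccc(C(F)(F)F)c2)cc1)S(C)(=O)=O`: 601 nM
- Compound 2, `CC(C)CS(=O)(=O)N(Cc1ccc(-c2cccc(F)c2)cc1)[C@@H](C)C(=O)N[C@H](C#N)CC(N)=O`: 2270 nM

In an assay on isolated protein for inhibition of legumain (Homo sapiens), with stated times of 2 min and 60 min (a higher number here means a weaker inhibitor, a lower number a stronger inhibitor), compound 2 gives 2270 nM, the highest of the two numbers recorded. Its only companion, compound 1, gives 601 nM in this assay, a lower number, and the gap between these two values lies beyond the usual scatter, so compound 2 stands as the weaker inhibitor of the pair. The two compounds differ in more than one place, so the gap cannot be traced to a single change.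

Compound 3, `C[C@@H](C(=O)N[C@H](C#N)CC(N)=O)N(Cc1ccc(-c2cccc(F)c2)cc1)S(=O)(=O)c1ccccc1`, is not yet measured. It keeps the shared core of compound 2 and introduces a single change: phenyl in place of isobutyl on a sulfonyl sulfur. Within the data shown here, no step between measured compounds bears on this exchange, so the direction of its effect is open. The exchange is expected to shift the result only modestly, with a 1.5-fold lower number from compound 2 to compound 3 (0.18 log units; within the scatter) the estimated step in this assay and no strong lean either way. For compound 3 the value in this assay is expected to be about 1500 nM, with a likely range from 500 nM to 4500 nM.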

Compound 3, half-maximal inhibitory concentration: > 10000 nM
Compound 3: only a limit was reported; the forecaster's own chance of this, stated with the estimate: 5%; middle value at least 6.6-fold (0.82 log units) from the limit.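

Among these compounds, the sulfonyl sulfur, whose other neighbour is the sulfonamide nitrogen, proves sensitive to the group it carries: phenyl in place of isobutyl gives an at least 4.4-fold higher number from compound 2 to compound 3 (0.64 log units; beyond the scatter) in this assay, a step beyond the scatter and the first reading of a single change at this place. Compound 3 has no exact value, only a limit of > 10000 nM. The step therefore gives a bound and not a size, and it rests on that one limit: the limit of > 10000 nM in this assay, at which 1 of the 3 values shown sits.

The compounds shown leave open whether the loss follows from the aromatic ring of phenyl or from some other difference between the two groups, and a cyclohexyl or benzyl group on the same sulfur would begin to separate these possibilities. From the compounds shown here alone, the methyl on the sulfonyl sulfur of compound 1 offers no help here, as compound 1 differs from compound 2 in more than one place, so how a shorter chain on this sulfur compares with isobutyl with the rest of compound 2 unchanged remains unknown.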